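Cytotoxicity of stilbene benzyl ethers with polar amine tails

This account rests on a few compounds, and the source may have more. Where it says the series, first, only, none or still open, it means among the compounds named here.

The series shares a stilbene core carrying a benzyloxy arm, with differing amine groups on a saturated chain carbon bound to an aromatic carbon. Compound 1 `COc1ccc(/C=C\c2cc(OC)c(OC)c(OC)c2)cc1OCc1ccc(CN2CCCC[C@H]2C(=O)O)cc1` carries 2-carboxypiperidin-1-yl; compound 2 `COc1ccc(/C=C\c2cc(OC)c(OC)c(OC)c2)cc1OCc1ccc(CN2CC[C@H](O)C2)cc1` carries 3-hydroxypyrrolidin-1-yl; compound 3 `COc1ccc(/C=C\c2cc(OC)c(OC)c(OC)c2)cc1OCc1ccc(CN[C@H](C(=O)O)[C@@H](C)O)cc1` carries (1-carboxy-2-hydroxypropyl)amino. In an ADME assay on HEK293 cells (Homo sapiens) for cytotoxicity, read by CCK-8 assay, with a stated time of 48 h (on this read-out lower numbers stand for stronger inhibition and higher numbers for weaker inhibition), compound 1 returns only a limit, > 50000 nM. Compound 2 likewise returns only a limit in this assay, > 50000 nM. Compound 3 stands at a limit as well, > 50000 nM, so no number is known for it. The steps a step that the two limits leave unreadable from compound 1 to compound 2, a step that the two limits leave unreadable from compound 1 to compound 3 and a step that the two limits leave unreadable from compound 2 to compound 3 are all unreadable, because of the limit of > 50000 nM in this assay, at which 3 of the 3 values shown sit.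

Compound 4 `COc1ccc(/C=C\c2cc(OC)c(OC)c(OC)c2)cc1OCc1ccc(CN2CCCC[C@@H]2C(=O)O)cc1` differs from compound 3 in one place: 2-carboxypiperidin-1-yl in place of (1-carboxy-2-hydroxypropyl)amino on a saturated chain carbon bound to an aromatic carbon. The measured steps that bear on this change, exchanging one polar amine tail for another, all start and end at the limit, so they give no size in either direction. No shift beyond the scatter is therefore expected in this assay. Compound 4 is expected to give 60000 nM, with a range from 30000 nM to 150000 nM. The step that the limit leaves unreadable from compound 3 to compound 4 that this estimate means is expected to be flat, and most likely compound 4 will again return only a limit.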

Compound 4, half-maximal inhibitory concentration: 42000 nM
Estimate against measurement, compound 4: 1.4-fold (0.15 log units) above, and the stated range covers the measured number.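

In this assay compound 4 is the only compound shown that returns a number rather than a limit, which gives the exchange of polar amine tails on the saturated chain carbon a floor in place of an unreadable step: an at least 1.1-fold lower number from compound 3 to compound 4 (0.07 log units; that floor lies within the scatter) and an at least 1.1-fold lower number from compound 2 to compound 4 (0.07 log units; that floor lies within the scatter). Each step remains a floor rather than a size because its other end sits at a limit: the limit of > 50000 nM in this assay, at which 3 of the 4 values shown sit. The one comparison confined to a single feature is an at least 1.1-fold lower number from compound 1 to compound 4 (0.07 log units; that floor lies within the scatter), so any real gap in that step would belong to the stereocentre at the saturated ring carbon, drawn S in one compound and R in the other, because of this: the fact that compounds 1 and 4 differ only in the configuration as drawn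

Going by these compounds, how far compound 1, compound 2 and compound 3 lie past the limit stays open, and with it whether the configuration or the choice of tail changes the read-out beyond the scatter at all. Also open, on these data alone, is how a 2-carboxypyrrolidin-1-yl tail, or a piperidin-1-yl tail without the carboxylic acid, would read in this assay.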